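N-Alkyl variation on the ring nitrogen of a shared core

The compounds below may be only part of what the source reports. "The series", "measured", "known", "first", "only" and "open" are said of these compounds alone.

Measured so far:
compound 1 `CN1C(=O)C=C(Cl)C1(O)c1ccc(Cl)cc1`, 2000 nM
compound 2 `CC(C)N1C(=O)C=C(Cl)C1(O)c1ccc(Cl)cc1`, 300 nM

In an assay on cell membranes for displacement of a labelled ligand from Cholecystokinin receptor type A (Rattus norvegicus), read by CCK-8 assay, with a stated time of 2 h (on this read-out higher numbers stand for weaker inhibition and lower numbers for stronger inhibition), compound 1 gives 2000 nM and compound 2 gives 300 nM. Among the measured compounds shown here, the one step measured, a 6.7-fold lower number from compound 1 to compound 2 (0.82 log units; beyond the scatter), is isopropyl in place of methyl on an amide-type nitrogen in a ring. On the two numbers available, compound 2 stands lowest; its nearest neighbour is compound 1, a step beyond the scatter away.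

Compound 3 `O=C1C=C(Cl)C(O)(c2ccc(Cl)cc2)N1C1CCCC1` is not yet measured. It differs from compound 2 by cyclopentyl in place of isopropyl on an amide-type nitrogen in a ring, again on the amide-type nitrogen in a ring. For the measured compounds named here, the only step that bears on it is a 6.7-fold lower number from compound 1 to compound 2 (0.82 log units; beyond the scatter), where a larger alkyl group on that nitrogen went with a lower number. Whether a further enlargement continues that direction cannot be told from two compounds, so a smaller step is expected. Compound 3 is expected at 150 nM, range 50 nM to 600 nM, the expected step being a 2.0-fold lower number from compound 2 to compound 3 (0.30 log units; within the scatter).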

Compound 3, half-maximal inhibitory concentration: 2500 nM
Compound 3: middle estimate off by 17-fold (1.22 log units), on the low side, outside the stated range (above it).
By their numbers in this assay, from the lowest: compound 2; then compounds 1 and 3 (each within the scatter of the next).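

Enlarging the alkyl group on this amide-type nitrogen does not keep lowering the number: in this assay, cyclopentyl in place of isopropyl gives an 8.3-fold higher number from compound 2 to compound 3 (0.92 log units; beyond the scatter), which removes the gain that isopropyl brought. Cyclopentyl in place of methyl gives a 1.3-fold higher number from compound 1 to compound 3 (0.10 log units; within the scatter), so these two groups are not separated, and among the three compounds only the isopropyl compound 2 stands apart from the others by steps beyond the scatter. No measurement at hand accounts for this reversal.

Three groups cannot show whether the low number depends on the branched isopropyl shape or on a narrow range of chain length, and ethyl, n-propyl, tert-butyl or cyclopropyl on this nitrogen would bear on that. From the compounds shown here alone, the effect of replacing the hydroxy or chloro groups on the shared core also remains open.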